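Series notes: aryl exchange on the carbon double-bonded to nitrogen

The source may report more compounds than this note shows. Statements on the series, on what has been measured and on what is new or still open speak of the compounds shown alone.

Compound 1 `CC(c1ccc(-c2ccccc2)c(F)c1)c1nnc2n1N=C(c1ccc(Cl)cc1Cl)CS2` gives 4200 nM in a functional assay on Hep 3B2 cells (Homo sapiens) for inhibition, read by sulforhodamine B assay, with a stated time of 72 h; a higher number here means a weaker inhibitor, a lower number a stronger inhibitor. Compound 3 `CC(c1ccc(-c2ccccc2)c(F)c1)c1nnc2n1N=C(c1ccc([N+](=O)[O-])cc1)CS2` gives 2900 nM in this assay, so that a 1.4-fold lower number from compound 1 to compound 3 (0.16 log units; within the scatter). Compound 2 `CC(C)Cc1ccc(C(C)c2nnc3n2N=C(c2ccc(Br)cc2)CS3)cc1` gives 8300 nM; it stands highest of the three numbers, with compound 1 within the scatter of it and compound 3 beyond it. Compound 4 `COc1ccc(C2=Nn3c(nnc3C(C)c3ccc(CC(C)C)cc3)SC2)cc1` differs from compound 2 by methoxy in place of bromo on an aromatic carbon. Going by the values given here, the only measured step, from compound 1 to compound 3, alters the ring on the same carbon with a double bond to nitrogen and stays within the scatter; no measured step exchanges bromo for methoxy. No step beyond the scatter is therefore expected in this assay. Compound 4 is estimated at 7000 nM, between 3000 nM and 16000 nM, which means an expected 1.2-fold lower number from compound 2 to compound 4 (0.07 log units; within the scatter).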

Compound 4, half-maximal inhibitory concentration: 6500 nM
The estimate for compound 4 lay 1.1-fold (0.03 log units) above the measured number; measured number inside the range.
By their numbers in this assay, from the lowest: compounds 3, 1, 4 and 2 (each within the scatter of the next, the first and the last beyond it).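

In this assay, methoxy in place of bromo on the aromatic carbon gives a 1.3-fold lower number from compound 2 to compound 4 (0.11 log units; within the scatter). Going by these compounds alone, this is the first single-group exchange read on the 4-substituted phenyl ring itself, and bromo and methoxy cannot be told apart here, although one hydrogen-bond acceptor enters with methoxy. No supporting data bear on why the two compounds read alike.

On these data alone, whether an amine or a carboxylic acid at this position would also stay within the scatter remains open. Also open, as far as these compounds go, is whether the same exchange would read alike on the side chain of compound 1.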